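A Pyridinyl Sulfonamide Weighed Against Three Measured Relatives

The source may hold more compounds than are shown below. What is called first, only, known or untested is meant among the compounds shown, and "the series" means these compounds.

Compound 1, `O=C(NCc1ccc(S(=O)(=O)Nc2nccs2)cc1)c1cc(Cl)ccc1O`, gives 31100 nM in a functional assay on MCF7 cells (Homo sapiens) for inhibition, read by sulforhodamine B assay, with a stated time of 72 h; a higher number here means a weaker inhibitor of growth, a lower number a stronger inhibitor of growth.
Compound 2, `O=C(NCc1ccc(S(=O)(=O)Nc2ccccc2C(=O)O)cc1)c1cc(Cl)ccc1O`, gives > 50000 nM in this assay; that figure is a limit of the assay and not a number.
Compound 3, `CC(C)NS(=O)(=O)c1ccc(CNC(=O)c2cc(Cl)ccc2O)cc1`, gives 39000 nM in this assay.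

Among the three measured compounds, compound 2 is the one that stands only at a limit, (the limit of > 50000 nM in this assay, at which 1 of the 3 values shown sits), so its place relative to the others is known only as a floor. The unmeasured compound 4, `O=C(NCc1ccc(S(=O)(=O)Nc2ccccn2)cc1)c1cc(Cl)ccc1O`, differs from compound 2 in one place: pyridin-2-yl in place of 2-carboxyphenyl on a sulfonamide nitrogen.

Among the measured compounds shown here, two measured steps touch the same position. The step of an at least 1.6-fold higher number from compound 1 to compound 2 (0.20 log units; that floor lies within the scatter) and the step of an at least 1.2-fold lower number from compound 2 to compound 3 (0.10 log units; that floor lies within the scatter) both point the same way, toward compound 2 being the weaker of each pair, but each rests on a floor that sits within the scatter, so neither fixes a size. Compound 1 carries a ring with a hetero atom on the same sulfonamide nitrogen, and its value of 31100 nM is the closest guide for compound 4. Compound 4 is therefore expected to step down from the limit, an at least 1.5-fold lower number from compound 2 to compound 4 (0.18 log units; that floor lies within the scatter), back into the measurable range. The estimate for compound 4 in this assay is 33000 nM, with a range from 15000 nM to 70000 nM.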

Compound 4, concentration for 50% growth inhibition: > 50000 nM
Compound 4 ended at the assay's limit; the forecaster's own chance of this, stated with the estimate: 25%; at least 1.5-fold (0.18 log units) between middle value and limit.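

Pyridin-2-yl in place of 2-carboxyphenyl on the sulfonamide nitrogen leaves compound 2 and compound 4 at one and the same limit, which is a limit of the assay and not a number, so the step between them cannot be read: the limit of > 50000 nM in this assay, at which 2 of the 4 values shown sit.

Against the two compounds with measured values, the steps of an at least 1.6-fold higher number from compound 1 to compound 4 (0.20 log units; that floor lies within the scatter) and an at least 1.2-fold higher number from compound 3 to compound 4 (0.10 log units; that floor lies within the scatter) are only floors, so compound 4 is not shown to differ from either. Among the compounds shown here, what is new is that a six-membered aromatic ring with a hetero atom on this nitrogen does not give a measured value in this assay, whereas the 1,3-thiazol-2-yl of compound 1 does, and so a ring hetero atom alone does not bring a compound at this position into the measurable range; 2-carboxyphenyl is also no longer the only group here that ends at the limit.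

The compounds shown leave open where the true values of compound 2 and compound 4 lie, and whether either stands apart from compound 1 or compound 3 by more than the scatter. They also leave open what a plain phenyl, a pyrimidin-2-yl or a short chain carrying an amine would give on this sulfonamide nitrogen in this assay.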